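A few compounds are considered here, and "the series" means these few. Any claim that something is new, unique, unknown or untested is made for them only; others in the source may bear on it.

Working notes on a small triazole series tested in an assay on nucleic acid for inhibition of Nucleic Acid, read by fluorescence, tested at 100 uM; a higher number here means more inhibition at the concentration tested (going by the name of the read-out), a lower number less inhibition. Compound 1 `CN(CCCc1ccccc1)Cc1cn(CC(O)COC(=O)NCc2ccccc2)nn1` gives 79% in this assay. Compound 2 `O=C(OC1CCCCC1n1cc(CN2CCC(c3ccccc3)CC2)nn1)c1ccccc1` gives 16%. Compound 3 `CN(CCCc1ccccc1)Cc1cn(C2CCCCC2OC(=O)COc2ccccc2)nn1` gives 42%, which places it second of the three numbers: compound 2 lies nearest, a number beyond the scatter lower, and compound 1 lies furthest, a number beyond the scatter higher. Within the data shown here, no two measured compounds differ in one place only, so no single-point step can be read among them; compound 1 and compound 3 carry the same amine but differ in the group on the triazole nitrogen, and their values differ beyond the scatter.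

Compound 4 `CCOC(=O)C1CCCN(Cc2cn(C3CCCCC3OC(=O)COc3ccccc3)nn2)C1` is not yet measured. It differs from compound 3 in one place: 3-(ethoxycarbonyl)piperidin-1-yl in place of methyl(3-phenylpropyl)amino on a saturated chain carbon bound to an aromatic carbon. Among the measured compounds shown here, the only measured compound without the methyl(3-phenylpropyl)amino group is compound 2, and compound 2 gives 16% in this assay. On that basis a step downward beyond the scatter is expected, a number 17 percentage points lower from compound 3 to compound 4 (beyond the scatter), because compound 2 gives 16%. Compound 4 is estimated to give about 25%, with an expected range from 5% to 50%.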

Compound 4, a percentage reported as inhibition, at one concentration (the size of the read-out at that concentration, not a potency): 21%
Compound 4: the middle estimate sits 4 percentage points above what was measured; measured number inside the range.
By their numbers in this assay, from the lowest: compounds 2 and 4 (each within the scatter of the next); then compound 3; then compound 1.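

Among these compounds, this is the first step that changes one place with the rest of the molecule held, and in this assay it shows that the group on a saturated chain carbon bound to an aromatic carbon matters: replacing methyl(3-phenylpropyl)amino with 3-(ethoxycarbonyl)piperidin-1-yl gives a number 21 percentage points lower from compound 3 to compound 4 (beyond the scatter). The two groups have the same count of heavy atoms, so the step does not come with a change in that count, but the entering group has no six-membered aromatic ring of carbon only, and it brings two more hydrogen-bond acceptors, a non-aromatic ring with a hetero atom and a double bond outside aromatic rings, and this single step cannot separate these differences. No measurement at hand accounts for the size or direction of the step.

Going by these compounds, it remains open whether a plain piperidin-1-yl group or a piperidine bearing a carboxylic acid in place of the ethyl ester would stay close to compound 4 or move towards compound 3. On these data alone, it is also open whether a 4-phenylbutyl chain on the same nitrogen, in place of the 3-phenylpropyl chain, would keep the value of compound 3 at this position.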